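The compounds below may be only part of what the source reports. "The series", "measured", "known", "first", "only" and "open" are said of these compounds alone.

Measured so far in a functional assay on MCF7 cells (Homo sapiens) for cytotoxicity, read by MTT assay, with a stated time of 24 h, tested at 1.6 ug/mL; a higher number here means a stronger effect of the compound at the concentration tested, a lower number a weaker effect:
- compound 1, `Cn1c(-c2ccc(NC(=O)CSc3nc4ccccc4s3)cc2)nc(-c2ccccc2)c1-c1ccccc1`: compound 1 gives 2.1%
- compound 2, `Cn1cnnc1SCC(=O)Nc1ccc(-c2nc(-c3ccccc3)c(-c3ccccc3)n2C)cc1`: compound 2 gives 42.8%
- compound 3, `CN1CCN(CC(=O)Nc2ccc(-c3nc(-c4ccccc4)c(-c4ccccc4)n3C)cc2)CC1`: compound 3 gives 2.9%

Compound 3 stands second highest of the three numbers. Its nearest neighbour is compound 1, the step being a number 0.8 percentage points higher from compound 1 to compound 3 (within the scatter); its furthest is compound 2, from which it is reached by a number 39.9 percentage points lower from compound 2 to compound 3 (beyond the scatter). The only large movement in the set is a number 40.7 percentage points higher from compound 1 to compound 2 (beyond the scatter), and both large steps concern the exchange of the group on the sulfur or on the saturated chain carbon bound to the carbonyl carbon.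

Compound 4, `CCN1CCN(CC(=O)Nc2ccc(-c3nc(-c4ccccc4)c(-c4ccccc4)n3C)cc2)CC1`, differs from compound 3 in one place: methyl in place of hydrogen on a saturated chain carbon bound to an amine nitrogen in a ring. Among the compounds with values here, none of the three measured steps touches the substituent on the ring amine nitrogen; all of them alter the group carried by the chain carbon bound to the carbonyl carbon, so no measured step bears directly on this change. With nothing in the measured set pointing either way, the expectation is a step of a number 1.1 percentage points higher from compound 3 to compound 4 (within the scatter) in this assay, that is, no move beyond the scatter from compound 3.

Compound 4 is therefore estimated at 4%, with a range from 0% to 16%.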

Compound 4, a percentage reported as activity, at one concentration (the size of the read-out at that concentration, not a potency): 14.6%
Beside the measured number, compound 4's estimate is 10.6 percentage points below it; the measured number falls inside the stated range.
By their numbers in this assay, from the lowest: compounds 1 and 3 (each within the scatter of the next); then compound 4; then compound 2.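

Notes on the series: in this assay the group on the ring amine nitrogen, which no earlier step touched, proves able to move the read-out, with a number 11.7 percentage points higher from compound 3 to compound 4 (beyond the scatter) for 4-ethylpiperazin-1-yl against 4-methylpiperazin-1-yl. The piperazine side chain also now separates from the benzothiazole thioether: a number 0.8 percentage points higher from compound 1 to compound 3 (within the scatter) gave no distinction, whereas a number 12.5 percentage points higher from compound 1 to compound 4 (beyond the scatter) does, although a number 28.2 percentage points lower from compound 2 to compound 4 (beyond the scatter) shows that the ethyl compound does not reach the level of the methyltriazole thioether. No supporting data are available to explain the effect of this added carbon.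

As far as these compounds go, the ethyl result is a single step at one tested concentration, so it remains open whether a longer chain such as propyl or butyl on the same nitrogen would bring a further rise or a return towards compound 3. Also open, from the compounds shown here alone, is how a free secondary amine, a 2-hydroxyethyl group or a morpholine ring in place of the piperazine would read against the methyltriazole thioether of compound 2.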